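The compounds below may be only part of what the source reports. "The series", "measured", "known", "first", "only" and "open" are said of these compounds alone.

In a functional assay on A549 cells (Homo sapiens) for inhibition (a lower number here means a stronger inhibitor of growth, a higher number a weaker inhibitor of growth), compound 1 `O=S(=O)(Nc1ccccc1)c1ccccc1` is recorded only as a limit, > 80000 nM. Compound 2 `O=S(=O)(Nc1ccccc1)c1ccc(Br)cc1` gives 30000 nM and compound 3 `CC(C)(C)c1ccc(S(=O)(=O)Nc2ccccc2)cc1` gives 16000 nM, so compound 3 stands level with compound 2 within the scatter. Compound 4 `Cc1ccccc1NS(=O)(=O)c1ccc(C(C)(C)C)cc1` follows from compound 3 by methyl in place of hydrogen on an aromatic carbon, ortho to a large group, or phenyl to 2-methylphenyl. Among the compounds with values here, no measured step places a group at this site. Only loose guides exist: an at least 2.6-fold lower number from compound 1 to compound 2 (0.42 log units; beyond the scatter), an at least 5.0-fold lower number from compound 1 to compound 3 (0.69 log units; beyond the scatter) and a 1.9-fold lower number from compound 2 to compound 3 (0.27 log units; within the scatter). No step beyond the scatter is expected in this assay, and no direction can be firmly expected. The expected change is a 1.1-fold lower number from compound 3 to compound 4 (0.06 log units; within the scatter). Compound 4 is estimated at 14000 nM, with an expected range of 6000 nM to 35000 nM.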

Compound 4, concentration for 50% growth inhibition: > 80000 nM
Compound 4: a limit, no number (the forecaster's own chance of this, stated with the estimate: 8%); middle value at least 5.7-fold (0.75 log units) away from the limit.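

In this assay, methyl in place of hydrogen on this aromatic carbon gives an at least 5.0-fold higher number from compound 3 to compound 4 (0.69 log units; beyond the scatter), opposite in direction to an at least 5.0-fold lower number from compound 1 to compound 3 (0.69 log units; beyond the scatter). Within the data shown here, this site therefore responds to a single added methyl, which the earlier compounds could not show. Compound 4 is recorded only as a limit, so the full size of the step stays unknown: the limit of > 80000 nM in this assay, at which 2 of the 4 values shown sit.

From the compounds shown here alone, whether any group at this site gives the same result remains open, for example fluoro, methoxy or an amine. Also open, going by these compounds, is how methyl behaves on another carbon of this ring.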